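Methyl on the ring nitrogen: a chain-lengthening step revisited

This account rests on a few compounds, and the source may have more. Where it says the series, first, only, none or still open, it means among the compounds named here.

Compound 1 `COc1ccc(-c2cc3c(cn2)[nH]c(=O)n3-c2cc(OC)c(OC)c(OC)c2)cc1` gives 1210 nM in a functional assay on HeLa cells (Homo sapiens) for antiproliferative activity, read by MTT assay, with a stated time of 48 h; a higher number here means a weaker inhibitor, a lower number a stronger inhibitor. Compound 2 `CCOc1ccc(-c2cc3c(cn2)[nH]c(=O)n3-c2cc(OC)c(OC)c(OC)c2)cc1` differs from it by methyl in place of hydrogen on a saturated chain carbon bound to an oxygen on an aromatic ring, and in this assay compound 2 gives 3730 nM, a step of a 3.1-fold higher number from compound 1 to compound 2 (0.49 log units; beyond the scatter). Compound 3 `COc1ccc(-c2cc3c(cn2)n(C)c(=O)n3-c2cc(OC)c(OC)c(OC)c2)cc1O` gives 2220 nM in this assay; the difference between its core and that of compound 1 is not broken down here. Compound 4 `CCn1c(=O)n(-c2cc(OC)c(OC)c(OC)c2)c2cc(-c3ccc(OC)c(O)c3)ncc21` differs from compound 3 by methyl in place of hydrogen on a saturated chain carbon bound to an aromatic nitrogen. This is the same kind of change as that from compound 1 to compound 2, but the place differs: there the carbon is bound to an oxygen on an aromatic ring, here to an aromatic nitrogen. The step is expected to be a 2.0-fold higher number from compound 3 to compound 4 (0.31 log units; beyond the scatter), set beside a 3.1-fold higher number from compound 1 to compound 2 (0.49 log units; beyond the scatter) as a weakening of similar size, resting on that single measured pair. Compound 4 is therefore expected to give 4500 nM in this assay, between 1800 nM and 11000 nM.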

Compound 4, half-maximal inhibitory concentration: > 20000 nM
Compound 4 gave a limit, no number (the forecaster's own chance of this, stated with the estimate: 10%); middle value at least 4.4-fold (0.64 log units) away from the limit.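

In this assay the change from methyl to ethyl gives an at least 9.0-fold higher number from compound 3 to compound 4 (0.95 log units; beyond the scatter), a weakening in the same direction as on the core of compound 1, but the two steps differ in size: the same change on two cores in this assay, a 3.1-fold higher number (0.49 log units; beyond the scatter) from compound 1 to compound 2 and an at least 9.0-fold higher number (0.95 log units; beyond the scatter) from compound 3 to compound 4, at least 2.9-fold (0.46 log units) apart, beyond the scatter of two such steps. Compound 4 gives > 20000 nM, which is a limit of the assay and not a number: the limit of > 20000 nM in this assay, at which 1 of the 4 values shown sits. The change therefore does not carry a fixed size from one core to the other, but these two pairs do not show how large the second step really is, nor whether the core or the place of the change accounts for the gap.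

The compounds shown leave open how a longer chain, or a chain ending in an amine, would read on that aromatic nitrogen. They also leave open whether the same change at the same place on both cores would give steps of matching size.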